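Side-chain ester in place of the hydroxypropyl ether

The compounds below may be only part of what the source reports. "The series", "measured", "known", "first", "only" and "open" are said of these compounds alone.

Compound 1 `CC(C)=CC[C@@H](OCC(C)O)C1=CC(=O)c2c(O)ccc(O)c2C1=O` carries a 2-hydroxypropyl group on an oxygen on a saturated carbon. Within the data shown here, in a functional assay on HeLa cells (Homo sapiens) for cytotoxicity, read by MTT assay (on this read-out higher numbers stand for weaker inhibition and lower numbers for stronger inhibition), compound 1 gives 24700 nM, the lowest of the two numbers measured so far. Compound 2 `CCCCC(C)(O)CC(=O)O[C@H](CC=C(C)C)C1=CC(=O)c2c(O)ccc(O)c2C1=O` has a (2-hydroxy-2-methylhexyl)carbonyl group in that place; in this assay compound 2 gives 60600 nM, and the step of a 2.5-fold higher number from compound 1 to compound 2 (0.39 log units; beyond the scatter) lies beyond the scatter.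

Compound 3 `CCC(O)(CC)CC(=O)O[C@H](CC=C(C)C)C1=CC(=O)c2c(O)ccc(O)c2C1=O` is not yet measured. Its difference from compound 1 is (2-ethyl-2-hydroxybutyl)carbonyl in place of 2-hydroxypropyl on an oxygen on a saturated carbon. Among the measured compounds shown here, the change is of the same kind as the one leading to compound 2: the ether becomes an ester, and the entering group is a close relative of the (2-hydroxy-2-methylhexyl)carbonyl group of compound 2. For the measured compounds named here, the only measured step that bears on this is a 2.5-fold higher number from compound 1 to compound 2 (0.39 log units; beyond the scatter), which was modest. The expected outcome is therefore a step of similar size and the same direction, a 2.0-fold higher number from compound 1 to compound 3 (0.31 log units; beyond the scatter), towards a higher number. Compound 3 is estimated at 50000 nM, with a range of 25000 nM to 100000 nM.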

Compound 3, half-maximal inhibitory concentration: 52000 nM
Estimate against measurement, compound 3: 1.0-fold (0.02 log units) below; measured number inside the range.
By their numbers in this assay, from the lowest: compound 1; then compounds 3 and 2 (each within the scatter of the next).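

In this assay, a second ester on this oxygen moves the number the same way as the first: a 2.1-fold higher number from compound 1 to compound 3 (0.32 log units; beyond the scatter) sits alongside a 2.5-fold higher number from compound 1 to compound 2 (0.39 log units; beyond the scatter), so both esters shown read higher than the 2-hydroxypropyl ether of compound 1, and neither goes against this within the three compounds. The acyl side chain itself can be varied with little visible consequence, since 1-ethyl-1-hydroxypropyl in place of 1-hydroxy-1-methylpentyl on a saturated chain carbon bound to a carbonyl carbon gives a 1.2-fold lower number from compound 2 to compound 3 (0.07 log units; within the scatter), which does not separate the two esters from each other. Nothing on hand accounts for the gap between the ether and the esters.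

The compounds shown leave open whether the step follows from the ester link itself or from the larger entering group, as both change together in compound 2 and compound 3; a plain acetyl group on this oxygen, or a 2-hydroxypropyl group joined through a carbonyl, would bear on that. Also open, on these data alone, is how this position responds to a group of another kind, such as an amine or a carboxylic acid at the end of the side chain.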